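Plasma Stability Across Three Peptidomimetic Ester Analogues

The source may report more compounds than this note shows. Statements on the series, on what has been measured and on what is new or still open speak of the compounds shown alone.

Measured compounds:
compound 1, `CCOC(=O)/C=C/[C@H](CCC(N)=O)NC(=O)[C@H](CC(C)C)NC(=O)[C@H](CC(C)C)NC(=O)c1cccc(O)c1C`: > 6 h
compound 2, `CCOC(=O)/C=C/[C@H](CCC(N)=O)NC(=O)[C@@H]1Cc2ccccc2CN1C(=O)[C@@H](NC(=O)c1cccc(O)c1C)C(C)C`: > 6 h

The read-out throughout is an ADME assay on a cell-free system (plasma, Homo sapiens) for metabolic stability, with Plasma (Rattus norvegicus) as the target, with a stated time of 6 h; on this read-out higher numbers stand for a longer-lived compound and lower numbers for a shorter-lived compound. Compound 1 gives > 6 h in this assay, which is a limit of the measurement and not a number. Compound 2 likewise gives > 6 h in this assay, again a limit rather than a number. Compound 2 therefore stands at the limit of > 6 h in this assay, at which 2 of the 2 values shown sit, so no ordering between the two measured compounds can be drawn from these results.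

Compound 3, `CCOC(=O)/C=C/[C@H](CC(C)C)NC(=O)[C@@H]1Cc2ccccc2CN1C(=O)[C@@H](NC(=O)c1cccc(O)c1C)C(C)C`, has not yet been measured in this assay. It differs from compound 2 by isopropyl in place of carbamoylmethyl on a saturated chain carbon, two bonds along the chain from an amide-type nitrogen and a double-bonded chain carbon. Going by the values given here, no step between measured compounds is available, so the effect of this change is open. With both measured compounds resting at the limit, compound 3 is expected to show essentially no step beyond the scatter, and the estimated step that the limit leaves unreadable from compound 2 to compound 3 is taken as flat. On that basis compound 3 is estimated at 8 h in this assay, within a range from 5 h to 12 h, with a high chance that only a limit is reported.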

Compound 3, half-life: > 6 h
Compound 3: a limit, no number; the forecaster's own chance of this, stated with the estimate: 80%; the middle value is on the limit's open side.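

In this assay compound 3 gives > 6 h, which is a limit and not a number. Going by these compounds alone, no step from compound 2 to compound 3 can be read, since all the values rest on the same limit: the limit of > 6 h in this assay, at which 3 of the 3 values shown sit. The compounds shown leave open what the actual half-lives are, and whether isopropyl in place of carbamoylmethyl alters the half-life at all.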